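The source may hold more compounds than are shown below. What is called first, only, known or untested is meant among the compounds shown, and "the series" means these compounds.

In a functional assay on V79 cells (Cricetulus griseus) for cytotoxicity, read by colony formation (a lower number here means a stronger inhibitor, a higher number a weaker inhibitor), compound 2 `O=C(O)c1cn(C2CC2)c2c(C(F)(F)F)c(N3CCCC3)c(F)cc2c1=O` gives 280 ug/mL, the only single number shown there. Compound 4 `CCNCC1CCN(c2c(F)cc3c(=O)c(C(=O)O)cn(C4CC4)c3c2C(F)(F)F)C1` differs from compound 2 by (ethylamino)methyl in place of hydrogen on a saturated ring carbon. The same group is carried by compound 1 `CCNCC1CCN(c2c(F)cc3c(=O)c(C(=O)O)cn(C4CC4)c3c2F)C1`, and compound 1 gives 11 ug/mL; 11 ug/mL; 11 ug/mL; 11 ug/mL (4 entries). Compound 3 `CCNCC1CCN(c2c(F)cc3c(=O)c(C(=O)O)cn(C4CC4)c3c2Cl)C1` carries it too, and compound 3 gives 11 ug/mL; 11 ug/mL; < 11 ug/mL (3 entries). The last entry of compound 3 is a limit of the assay and not a number. On the reading of compound 1 at 11 ug/mL; 11 ug/mL; 11 ug/mL; 11 ug/mL (4 entries), a large move towards a stronger inhibitor is expected in this assay, an estimated 19-fold lower number from compound 2 to compound 4 (1.27 log units; beyond the scatter). For compound 4 the expected value is 15 ug/mL, within an estimated range of 6 ug/mL to 40 ug/mL.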

Compound 4, half-maximal inhibitory concentration: 120 ug/mL
Beside the measured number, compound 4's estimate is 8.0-fold (0.90 log units) below it, outside the stated range (above it).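

In this assay, (ethylamino)methyl in place of hydrogen on the saturated ring carbon gives a 2.3-fold lower number from compound 2 to compound 4 (0.37 log units; beyond the scatter), so with trifluoromethyl on the core this change lowers the number only modestly. Compound 4 still reads higher than compound 1, which gives 11 ug/mL; 11 ug/mL; 11 ug/mL; 11 ug/mL (4 entries). Compound 3 offers a less firm comparison, and its last entry is a limit of the assay: the several entries of compound 3 in this assay, 11 ug/mL; 11 ug/mL; < 11 ug/mL (3 entries)

Going by these compounds, it remains open whether aminomethyl or (propylamino)methyl on this carbon would move the number further. Also open, on these data alone, is whether the step would have the same size on the core of compound 1 or compound 3, starting from pyrrolidin-1-yl.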